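The compounds below may be only part of what the source reports. "The series", "measured", "known", "first", "only" and "open" are said of these compounds alone.

Among the measured compounds shown here, compound 2 `COc1cc(N(C)C)c(NC(=O)c2ccccn2)cc1Nc1nccc(-c2cn(C)c3ccccc23)n1` gives 10400 nM in a functional assay on NCI-H1975 cells (Homo sapiens) for antiproliferative activity, read by MTT assay, with a stated time of 72 h (a higher number here means a weaker inhibitor, a lower number a stronger inhibitor), the highest of the two numbers measured so far; its nearest neighbour, compound 1 `COc1cc(N(C)C)c(NC(=O)c2ccncc2)cc1Nc1nccc(-c2cn(C)c3ccccc23)n1`, gives 1470 nM in this assay. For the measured compounds named here, the only step between measured compounds, a 7.1-fold higher number from compound 1 to compound 2 (0.85 log units; beyond the scatter), sits on the same carbonyl carbon and shows that exchanging one ring for another there can shift the number by a clear margin. Compound 3 `COc1cc(N(C)C)c(NC(=O)c2nccn2C)cc1Nc1nccc(-c2cn(C)c3ccccc23)n1` is not yet measured; it differs from compound 2 in that (1-methyl-1H-imidazol-2-yl in place of pyridin-2-yl on a carbonyl carbon). Going by the values given here, no measured pair shows this particular exchange, so neither the direction nor the size of the step can be read from compound 1 and compound 2; the one known step suggests only that such swaps need not be neutral. The estimate for compound 3 in this assay is therefore 6000 nM, expected to fall between 1500 nM and 25000 nM. The expected step is then a 1.7-fold lower number from compound 2 to compound 3 (0.24 log units; within the scatter).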

Compound 3, half-maximal inhibitory concentration: 2880 nM
Beside the measured number, compound 3's estimate is 2.1-fold (0.32 log units) above it, within the range that was stated.
By their numbers in this assay, from the lowest: compounds 1 and 3 (each within the scatter of the next); then compound 2.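

In this assay, the swap gives a 3.6-fold lower number from compound 2 to compound 3 (0.56 log units; beyond the scatter), so a five-membered ring carrying a methyl group can stand on this carbonyl carbon, and a six-membered ring is not required there. The two groups that compound 1 and compound 3 carry cannot be told apart in this assay: the step is a 2.0-fold higher number from compound 1 to compound 3 (0.29 log units; within the scatter). Of the three groups on this carbonyl carbon, pyridin-2-yl now stands apart, since its steps to both others lie beyond the scatter, while ring size alone does not sort the numbers.

Nothing available explains why pyridin-2-yl differs from the other two groups. Also open, as far as these compounds go, is whether a plain phenyl ring, a saturated amine such as morpholine or an open alkyl chain on this carbonyl carbon would give a similar number.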